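Compound 3 to compound 4: removing the methyl

This account rests on a few compounds, and the source may have more. Where it says the series, first, only, none or still open, it means among the compounds named here.

compound 1 `N#Cc1cc2c(nc1N1CCC(C(=O)NS(=O)(=O)Cc3ccccc3)CC1)CCC(F)C2=O` – 255000 nM
compound 2 `N#Cc1cc2c(nc1N1CCC(C(=O)NS(=O)(=O)Cc3ccccc3)CC1)CCC(Cl)C2=O` – > 300000 nM (a limit)
compound 3 `CN1Cc2nc(N3CCC(C(=O)NS(=O)(=O)Cc4ccccc4)CC3)c(C#N)cc2C1=O` – > 300000 nM (a limit)

In a functional assay (Platelet, plasma) for inhibition, with Homo sapiens as the target (a lower number here means a stronger inhibitor, a higher number a weaker inhibitor), compound 3 gives > 300000 nM as a limit and not as a number. Compound 3 therefore sits at the limit of > 300000 nM in this assay, at which 2 of the 3 values shown sit, and no exact value can be read for it.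

Compound 4 `N#Cc1cc2c(nc1N1CCC(C(=O)NS(=O)(=O)Cc3ccccc3)CC1)CNC2=O` is the next case, and its difference from compound 3 is hydrogen in place of methyl on an amide-type nitrogen in a ring. Among the compounds with values here, the one measured step is an at least 1.1-fold higher number from compound 1 to compound 2 (0.07 log units; that floor lies within the scatter) and it concerns chloro in place of fluoro on a saturated ring carbon, so it bears on this change only indirectly. Within the data shown here, compound 1 at 255000 nM is the only value that is a number, and it gives no reason to expect a step beyond the scatter in this assay in either direction. The estimated step is a number no higher from compound 3 to compound 4 (the limit leaves the size open) and it is read against a limit. For compound 4 the expected value is 300000 nM with an estimated range from 130000 nM to 700000 nM and a report as a limit is the likelier outcome.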

Compound 4, half-maximal inhibitory concentration: > 300000 nM
Compound 4 gave a limit, no number; the forecaster's own chance of this, stated with the estimate: 65%; the middle value sits exactly at the limit.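

In this assay compound 4 gives > 300000 nM, a limit and not a number. Compound 3 also stands only as a limit, so no step from compound 3 to compound 4 can be read: the limit of > 300000 nM in this assay, at which 3 of the 4 values shown sit.

The compounds shown leave open both the size and the direction of the effect of hydrogen in place of methyl on an amide-type nitrogen in a ring.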